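Swapping methyl for cyano on an aromatic carbon

This account rests on a few compounds, and the source may have more. Where it says the series, first, only, none or still open, it means among the compounds named here.

compound 1 `CCc1ccc(OC)c(COc2ccc(Cl)c(C)c2)c1` gives 40000 nM
compound 2 `COc1ccc(/C=C/c2cc(C(N)=O)ccc2OC)cc1` gives 8800 nM
compound 3 `COc1ccc(C(N)=O)cc1/C=C/c1cccc(C)c1` gives 3900 nM

These numbers come from a functional assay on HUVEC cells (Homo sapiens) for inhibition, with a stated time of 4 days (on this read-out higher numbers stand for weaker inhibition and lower numbers for stronger inhibition), and so a smaller number is the better result. Compound 3 has the lowest number of the three, and its gaps to compound 2 and compound 1 both exceed the usual scatter, which makes it the strongest inhibitor measured so far.

Compound 4 `COc1ccc(C(N)=O)cc1/C=C/c1cccc(C#N)c1` keeps the shared core of compound 3 but carries cyano in place of methyl on an aromatic carbon, meta to a large group (cyano in place of methyl on an aromatic carbon). Going by the values given here, no two measured compounds differ in just one place, so this swap has no direct precedent here. Among the compounds with values here, the only rough guide is that compound 2 (8800 nM) and compound 3 (3900 nM) lie fairly close together in this assay despite their different structures.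

A modest move towards weaker inhibition is expected, estimated as a 1.5-fold higher number from compound 3 to compound 4 (0.19 log units; within the scatter) and possibly no larger than the scatter. For compound 4 the estimated value is 6000 nM with an expected range from 2000 nM to 20000 nM in this measurement.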

Compound 4, half-maximal inhibitory concentration: 49000 nM
The estimate for compound 4 lay 8.2-fold (0.91 log units) below the measured number; measured number outside the range, above it.
By their numbers in this assay, from the lowest: compound 3; then compound 2; then compounds 1 and 4 (each within the scatter of the next).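

In this assay, going by these compounds alone, cyano in place of methyl on this aromatic carbon, meta to a large group, gives a 13-fold higher number from compound 3 to compound 4 (1.10 log units; beyond the scatter) and is the first change in this set that can be read in one place. This carbon is therefore far from indifferent to what it carries: with the rest of the structure held constant, methyl gives much stronger inhibition than cyano. Nothing measured here accounts for the size of this step.

Going by these compounds, whether methyl helps or cyano harms stays open, and a compound with plain hydrogen on this carbon would be needed to separate the two. How a fluorine atom, an amine or a carboxylic acid would fare at the same carbon is equally unknown.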